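Benzyl for Acetyl on a Fused Ring Amine Nitrogen

The source may hold more compounds than are shown below. What is called first, only, known or untested is meant among the compounds shown, and "the series" means these compounds.

Measured compounds:
compound 1 `N=C1S/C(=C\c2ccc(OCc3ccccc3)cc2)C(=O)N1c1ccccc1[N+](=O)[O-]`: 24.4%
compound 2 `Cc1cccc(C)c1N1C(=N)S/C(=C\c2ccc(OCc3ccccc3)cc2)C1=O`: 38.7%
compound 3 `CC(=O)N1CCc2c(sc(NC(=O)c3ccc(Cl)cc3)c2C(N)=O)C1`: 38.4%

In an ADME assay on RAW264.7 cells (Mus musculus) for cytotoxicity, read by MTT assay, with a stated time of 48 h, tested at 50 uM (on this read-out lower numbers stand for less inhibition and higher numbers for more inhibition at the one concentration tested (going by the name of the read-out)), compound 3 gives 38.4%, the second highest of the three numbers; compound 2 sits within the scatter of it, while compound 1 lies lower by more than the scatter. Compound 4 `NC(=O)c1c(NC(=O)c2ccc(Cl)cc2)sc2c1CCN(Cc1ccccc1)C2` differs from compound 3 by benzyl in place of acetyl on an amine nitrogen in a ring. Going by the values given here, the one measured step, a number 14.3 percentage points higher from compound 1 to compound 2 (beyond the scatter), concerns a different core and a different place, so it does not bear on this exchange. Among the compounds with values here, no measured step thus shows how this assay answers to the change, and the expected step is none beyond the scatter. Compound 4 is estimated at 38%, in a range from 22% to 55%, which means an expected step of a number 0.4 percentage points lower from compound 3 to compound 4 (within the scatter).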

Compound 4, a percentage reported as inhibition, at one concentration (the size of the read-out at that concentration, not a potency): 11.1%
For compound 4 the middle estimate is 26.9 percentage points above the measured one; the measured number lies below the stated range.
By their numbers in this assay, from the lowest: compound 4; then compound 1; then compounds 3 and 2 (each within the scatter of the next).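

Going by these compounds alone, on the amine nitrogen in a ring of the shared core, the exchange of acetyl for benzyl gives, in this assay, a number 27.3 percentage points lower from compound 3 to compound 4 (beyond the scatter), the first readable change at this position. The group on this nitrogen can therefore move the number at the one concentration tested. Nothing available explains this drop.

As far as these compounds go, it remains open whether the number follows the arrival of the benzyl group or the departure of acetyl. A free ring amine, a methyl group or a longer chain such as phenethyl on this nitrogen could tell these two apart.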